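The source may report more compounds than this note shows. Statements on the series, on what has been measured and on what is new or still open speak of the compounds shown alone.

- Compound 1 `Cc1cn([C@H]2C[C@H](N=[N+]=[N-])[C@@H](COP(=O)(O)Oc3ccc(Br)cc3)O2)c(=O)[nH]c1=O` gives 7.97 h
- Compound 2 `Cc1cn([C@H]2C[C@H](N=[N+]=[N-])[C@@H](COP(=O)(O)Oc3ccc(C#N)cc3)O2)c(=O)[nH]c1=O` gives 7.08 h
- Compound 3 `Cc1cn([C@H]2C[C@H](N=[N+]=[N-])[C@@H](COP(=O)(O)Oc3ccccc3)O2)c(=O)[nH]c1=O` gives 9.47 h

These values come from a physicochemical assay for metabolic stability, read by HPLC; a higher number here means that the compound lasts longer, a lower number that the compound disappears faster. Compound 3 stands level with the other two, within the scatter of both. Compound 4 `Cc1cn([C@H]2C[C@H](N=[N+]=[N-])[C@@H](COP(=O)(O)Oc3ccc(Cl)cc3)O2)c(=O)[nH]c1=O` is still unmeasured. It has chloro in place of hydrogen on an aromatic carbon, para to a large group (chloro in place of hydrogen on an aromatic carbon). The closest evidence comes from compound 1 and compound 2, which carry bromo and cyano on that carbon. Swapping either group for hydrogen moved the number very little (a 1.2-fold higher number from compound 1 to compound 3 (0.07 log units; within the scatter) and a 1.3-fold higher number from compound 2 to compound 3 (0.13 log units; within the scatter)). A similar swap is therefore expected to give no step beyond the scatter in this assay (a 1.1-fold lower number from compound 3 to compound 4 (0.06 log units; within the scatter)). For compound 4 the estimated half-life is 8.3 h, with an expected range from 5.5 h to 12.5 h.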

Compound 4, half-life: 5.5 h
Compound 4: middle estimate off by 1.5-fold (0.18 log units), on the high side; the range from low to high includes it.
By their numbers in this assay, from the lowest: compounds 4, 2, 1 and 3 (each within the scatter of the next).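

Chloro on this aromatic carbon stays within the scatter of all three earlier compounds in this assay (a 1.7-fold lower number from compound 3 to compound 4 (0.24 log units; within the scatter); a 1.3-fold lower number from compound 2 to compound 4 (0.11 log units; within the scatter); a 1.4-fold lower number from compound 1 to compound 4 (0.16 log units; within the scatter)). Across hydrogen, bromo, cyano and chloro, then, no swap at this position has yet given a step that stands clear of repeat-measurement noise. Nothing measured here bears on the small differences seen.

Going by these compounds, it remains open whether an amine, a carboxylic acid or a longer chain on this carbon would move the half-life beyond the scatter.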